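Chloro to Fluoro on the Hydrazone Aryl Ring

The source may report more compounds than this note shows. Statements on the series, on what has been measured and on what is new or still open speak of the compounds shown alone.

Compound 1 `COc1cc2c(Oc3ccc(NC(=O)N/N=C/c4ccc(F)cc4Cl)cc3F)ccnc2cc1OCCCN1CCCCC1`: 270 nM
Compound 2 `COc1ccc(/C=N/NC(=O)Nc2ccc(Oc3ccnc4cc(OCCCN5CCC(C)CC5)c(OC)cc34)c(F)c2)cc1`: 470 nM
Compound 3 `COc1cc2c(Oc3ccc(NC(=O)N/N=C/c4ccc(Cl)cc4Cl)cc3F)ccnc2cc1OCCCN1CCC(C)CC1`: 350 nM

In a functional assay on MKN-45 cells (Homo sapiens) for cytotoxicity, read by MTT assay, with a stated time of 72 h (on this read-out higher numbers stand for weaker inhibition and lower numbers for stronger inhibition), compound 3 gives 350 nM, the second highest of the three numbers; compound 1 is nearest and compound 2 furthest, and both gaps lie within the scatter. Compound 4 `COc1cc2c(Oc3ccc(NC(=O)N/N=C/c4ccc(F)cc4Cl)cc3F)ccnc2cc1OCCCN1CCC(C)CC1` differs from compound 3 in one place: fluoro in place of chloro on an aromatic carbon. For the measured compounds named here, the only measured step on that same aromatic ring is a 1.3-fold lower number from compound 2 to compound 3 (0.13 log units; within the scatter), which stayed within the scatter even for a larger swap. Compound 1 carries the same 2-chloro-4-fluorophenyl group with a different amine, and its number sits close to that of compound 3. A change no larger than the scatter is therefore expected, a 1.2-fold lower number from compound 3 to compound 4 (0.07 log units; within the scatter). Compound 4 is estimated at 300 nM, between 150 nM and 650 nM.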

Compound 4, half-maximal inhibitory concentration: 530 nM
Estimate against measurement, compound 4: 1.8-fold (0.25 log units) below; the measured number falls inside the stated range.
By their numbers in this assay, from the lowest: compounds 1, 3, 2 and 4 (each within the scatter of the next).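

In this assay, fluoro and chloro at this position cannot be told apart (a 1.5-fold higher number from compound 3 to compound 4 (0.18 log units; within the scatter)), so this ring carbon accepts either halogen without a change beyond the scatter. The same holds for the whole aryl group (a 1.1-fold higher number from compound 2 to compound 4 (0.05 log units; within the scatter)) and for methyl in place of hydrogen on the saturated ring (a 2.0-fold higher number from compound 1 to compound 4 (0.29 log units; within the scatter)). No measurement shown gives a reason for these small differences.

From the compounds shown here alone, whether bromo, nitrile or trifluoromethyl at this position would also stay within the scatter remains open. So does the effect of a hydrogen here.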